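This account rests on a few compounds, and the source may have more. Where it says the series, first, only, none or still open, it means among the compounds named here.

Measured compounds:
- compound 1 `Cc1nc(N)c(C#N)c(N[C@@H](C)c2cc3ccc(F)cn3c(=O)c2-c2ccccc2)n1`: "not determined" (no result reported)
- compound 2 `Cc1nc(N)nc(N[C@@H](C)c2cc3ccc(F)cn3c(=O)c2-c2ccccc2)c1C#N`: 41%

For the measured compounds named here, in an ADME assay on microsomes from liver (Rattus norvegicus), read by LC-MS, using NADPH, with a stated time of 30 min, tested at 1 uM (a lower number here means that less of the compound is left, a higher number that more of the compound is left), compound 2 gives 41%, the only number available, since for compound 1 no result was reported. Compound 3 `Cc1nc(N)nc(N[C@@H](C)c2c(-c3ccccc3)c(=O)n3cc(F)ccc3c2-c2ccc(F)cc2)c1C#N` is not yet measured; it differs from compound 2 by 4-fluorophenyl in place of hydrogen on an aromatic carbon, a 4-fluorophenyl in place of hydrogen on an aromatic carbon. No step between measured compounds is known, so nothing shown bears directly on this change. A downward step beyond the scatter is nonetheless expected for compound 3, a number 16 percentage points lower from compound 2 to compound 3 (beyond the scatter). The estimated value for compound 3 is 25%, with a range from 8% to 45%.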

Compound 3, percent of the compound remaining: 85%
Estimate against measurement, compound 3: 60 percentage points below; measured number outside the range, above it.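

In this assay, for the compounds shown here, the first step at this position is a large one: 4-fluorophenyl in place of hydrogen on this aromatic carbon, ortho to a fused ring and two atoms from the ring nitrogen, gives a number 44 percentage points higher from compound 2 to compound 3 (beyond the scatter). A single substituent at this carbon can therefore move the read-out strongly upward. Nothing available accounts for this rise. From the compounds shown here alone, whether the ring itself or its fluorine carries the change stays open, as does how an unsubstituted phenyl, a methyl or an amine at this carbon would read.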